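The compounds below may be only part of what the source reports. "The series", "measured", "known", "first", "only" and "open" are said of these compounds alone.

Compound 1 `O=C(Nc1ccc(Cl)cc1)Nc1nn(-c2ccccc2)c(=O)c2ccccc12` gives 13% in an assay on CHO cells for displacement of a labelled ligand from adenosine receptor A3 (Homo sapiens), tested at 1 uM; a lower number here means less inhibition, a higher number more inhibition at the concentration tested (going by the name of the read-out). Compound 2 `COc1ccc(C(=O)Nc2nn(-c3ccccc3)c(=O)c3ccccc23)cc1` gives 10%. Compound 3 `CC(=O)N(C(C)=O)c1nn(-c2ccccc2)c(=O)c2ccccc12` gives 0%.

Compound 3 shows the lowest of the three numbers, though its gap to compound 2 is within the scatter, and only compound 1 stands clearly beyond it. The next compound, compound 4 `O=C(Nc1nn(-c2ccccc2)c(=O)c2ccccc12)c1ccco1`, differs from compound 3 in one place: ((furan-2-yl)carbonyl)amino in place of diacetylamino on an aromatic carbon. The entering group carries one hydrogen-bond donor, as do the groups on compounds 1 and 2, while diacetylamino carries none. Among the compounds with values here, the only measured step, a number 3 percentage points lower from compound 1 to compound 2 (within the scatter), shows that exchanging one carbonyl substituent for another left the number essentially unchanged, so the part of compound 4 beyond the amide bears little on the outcome. Compound 4 most resembles compound 2, which gives 10%. A modest rise is therefore expected, a number 10 percentage points higher from compound 3 to compound 4 (within the scatter), at the edge of the scatter. Compound 4 is estimated at 10%, with a likely range from 0% to 25%.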

Compound 4, a percentage reported as inhibition, at one concentration (the size of the read-out at that concentration, not a potency): 8%
Compound 4: middle estimate off by 2 percentage points, on the high side; measured number inside the range.
By their numbers in this assay, from the lowest: compounds 3, 4, 2 and 1 (each within the scatter of the next, the first and the last beyond it).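

In this assay, ((furan-2-yl)carbonyl)amino in place of diacetylamino on this aromatic carbon gives a step that stays within the usual scatter (a number 8 percentage points higher from compound 3 to compound 4 (within the scatter)), so here the gain of the amide hydrogen does not clearly separate the two compounds. The furan-2-yl group, a five-membered aromatic ring, also gives no step beyond the scatter on the carbonyl carbon, whether it replaces 4-methoxyphenyl (a number 2 percentage points lower from compound 2 to compound 4 (within the scatter)) or (4-chlorophenyl)amino (a number 5 percentage points lower from compound 1 to compound 4 (within the scatter)). No independent measurement is available to explain any of these numbers.

The compounds shown leave open how a free amine on this aromatic carbon, with no carbonyl attached, would read in this assay. They also leave open whether a single acetyl on that nitrogen, or a longer alkyl chain on the carbonyl carbon, would fall within the scatter of compound 4.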